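The source may report more compounds than this note shows. Statements on the series, on what has been measured and on what is new or still open speak of the compounds shown alone.

Measured compounds:
Compound 1 `COc1cc2oc(-c3cccc(NC(=O)c4ccccc4)c3)cc(=O)c2c(OC)c1OC`: 11700 nM
Compound 2 `COc1cc2oc(-c3cccc(NC(=O)c4cccc(Br)c4)c3)cc(=O)c2c(OC)c1OC`: 10900 nM
Compound 3 `COc1cc2oc(-c3cccc(NC(=O)c4ccccc4Br)c3)cc(=O)c2c(OC)c1OC`: 23100 nM

In a functional assay on HepG2 cells (Homo sapiens) for inhibition, read by MTT assay (on this read-out higher numbers stand for weaker inhibition of growth and lower numbers for stronger inhibition of growth), compound 1 gives 11700 nM, the second highest of the three numbers. The nearest number is reached by a 1.1-fold lower number from compound 1 to compound 2 (0.03 log units; within the scatter), the furthest by a 2.0-fold higher number from compound 1 to compound 3 (0.30 log units; within the scatter). Going by the values given here, the only step that goes beyond the scatter is a 2.1-fold higher number from compound 2 to compound 3 (0.33 log units; beyond the scatter).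

Compound 4 `COc1cc2oc(-c3cccc(NC(=O)c4cccc(C#N)c4)c3)cc(=O)c2c(OC)c1OC` differs from compound 1 in one place: cyano in place of hydrogen on an aromatic carbon. Both measured steps from compound 1 put a bromo group onto the same outer ring, and one of them sits meta to the large group, exactly where the cyano group of compound 4 enters. Among the compounds with values here, neither of those steps moved the number beyond the scatter, so the one change that bears most directly on compound 4, a 1.1-fold lower number from compound 1 to compound 2 (0.03 log units; within the scatter), speaks for no step in this assay beyond the scatter in either direction.

Compound 4 is therefore expected to give about 11000 nM, with a range from 5500 nM to 22000 nM. For compound 4 this estimate means a 1.1-fold lower number from compound 1 to compound 4 (0.03 log units; within the scatter).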

Compound 4, concentration for 50% growth inhibition: 11900 nM
For compound 4 the middle estimate is 1.1-fold (0.03 log units) below the measured one, within the range that was stated.
By their numbers in this assay, from the lowest: compounds 2, 1, 4 and 3 (each within the scatter of the next, the first and the last beyond it).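

In this assay a cyano group on this carbon of the outer phenyl ring, meta to a large group, does no more than hydrogen does, with a 1.0-fold higher number from compound 1 to compound 4 (0.01 log units; within the scatter), so a first group other than bromo now shows no step beyond the scatter here. Exchanging bromo for cyano on this same carbon also stays small, with a 1.1-fold higher number from compound 2 to compound 4 (0.04 log units; within the scatter), and this position has now taken hydrogen, bromo and cyano with numbers that all lie within the scatter of one another. Going by these compounds alone, compound 3, the only compound beyond the scatter from compound 2, is not separated from the new compound either, with a 1.9-fold lower number from compound 3 to compound 4 (0.29 log units; within the scatter).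

No measurement shown explains why these numbers stay so close. Still open, as far as these compounds go, is whether an amine, a carboxylic acid or a longer chain on this carbon would move the number beyond the scatter.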